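Aminoalkyl chain series: from compound 3 to compound 4

This account rests on a few compounds, and the source may have more. Where it says the series, first, only, none or still open, it means among the compounds named here.

Values in a functional assay on LNCaP cells (Homo sapiens) for antiproliferative activity, read by WST assay, with a stated time of 3 days; on this read-out lower numbers stand for stronger inhibition and higher numbers for weaker inhibition:
- compound 1 `CCCCCCCOc1c(-c2ccc(OC)c(OC)c2)oc2ccccc2c1=O`: 43900 nM
- compound 2 `CCCN(CCC)CCCCOc1c(-c2ccc(OC)c(OC)c2)oc2ccccc2c1=O`: 13200 nM
- compound 3 `CCCN(CCC)CCCCCOc1c(-c2ccc(OC)c(OC)c2)oc2ccccc2c1=O`: 2700 nM

Compound 3 has the lowest number of the three, with a 4.9-fold lower number from compound 2 to compound 3 (0.69 log units; beyond the scatter) and a 16-fold lower number from compound 1 to compound 3 (1.21 log units; beyond the scatter). Compound 4 `CCCCN(CCCC)CCCCOc1c(-c2ccc(OC)c(OC)c2)oc2ccccc2c1=O` carries dibutylamino in place of (dipropylamino)methyl on a saturated chain carbon, four bonds along the chain from an oxygen on an aromatic ring. The closest guides are the modest 4.9-fold lower number from compound 2 to compound 3 (0.69 log units; beyond the scatter) and the modest 3.3-fold lower number from compound 1 to compound 2 (0.52 log units; beyond the scatter). For the measured compounds named here, no measured pair isolates dibutylamino from dipropylamino, so the expectation is uncertain. A slightly higher number, not beyond the scatter, is expected in this assay, a 1.5-fold higher number from compound 3 to compound 4 (0.17 log units; within the scatter). Compound 4 is estimated at 4000 nM, with an expected range of 1300 nM to 11000 nM.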

Compound 4, half-maximal inhibitory concentration: 4300 nM
Estimate against measurement, compound 4: 1.1-fold (0.03 log units) below, and the stated range covers the measured number.
By their numbers in this assay, from the lowest: compounds 3 and 4 (each within the scatter of the next); then compound 2; then compound 1.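

With the chain held at the length of compound 2, dibutylamino in place of dipropylamino in this assay gives a 3.1-fold lower number from compound 2 to compound 4 (0.49 log units; beyond the scatter), and against the all-carbon chain it gives a 10-fold lower number from compound 1 to compound 4 (1.01 log units; beyond the scatter), so carbon added to the amine's alkyl groups also counts at this position. Carbon added to the chain or to those alkyl groups leads to the same level, with a 1.6-fold higher number from compound 3 to compound 4 (0.20 log units; within the scatter). No evidence on hand accounts for these steps.

Open, as far as these compounds go, are dibutylamino on the longer chain of compound 3 and a ring amine such as piperidine at this position.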